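A few compounds are considered here, and "the series" means these few. Any claim that something is new, unique, unknown or untested is made for them only; others in the source may bear on it.

In a functional assay on MCF7 cells (Homo sapiens) for antiproliferative activity, read by MTT assay, with a stated time of 48 h (a lower number here means a stronger inhibitor, a higher number a weaker inhibitor), compound 1 (`O=[N+]([O-])c1cc(C(F)(F)F)cc([N+](=O)[O-])c1Oc1ccccc1/C=N\OCc1ccccc1`) gives 1330 nM as its half-maximal inhibitory concentration. Compound 2 (`O=[N+]([O-])c1cc(C(F)(F)F)cc([N+](=O)[O-])c1Oc1ccccc1/C=N/OCc1ccccc1Cl`) gives 1100 nM in the same test. Within the data shown here, these are the only two numbers available, and they lie within the usual scatter of each other, so compound 1 cannot be ranked against compound 2.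

Compound 3 (`O=[N+]([O-])c1cc(C(F)(F)F)cc([N+](=O)[O-])c1Oc1ccc(Cl)cc1/C=N\OCc1ccccc1`) is compound 1 with a single change: chloro in place of hydrogen on an aromatic carbon, meta to a large group and para to a large group. Among the measured compounds shown here, only one measured step bears on this. It also brings in a chlorine, but at a different place on the molecule, so it is indirect evidence. That step is a 1.2-fold lower number from compound 1 to compound 2 (0.08 log units; within the scatter) and it gives no sign of a real shift. No step beyond the scatter is therefore expected in this assay for the new chlorine, although a single indirect comparison justifies a wide range. The expected step is a 1.3-fold lower number from compound 1 to compound 3 (0.10 log units; within the scatter) on this estimate. For compound 3 the estimated value is 1050 nM with an expected range from 400 nM to 2600 nM in this test.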

Compound 3, half-maximal inhibitory concentration: 1220 nM
Compound 3: the middle estimate sits 1.2-fold (0.07 log units) below what was measured; low and high end bracket the measured number.
By their numbers in this assay, from the lowest: compounds 2, 3 and 1 (each within the scatter of the next).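

In this assay chloro in place of hydrogen gives a step that stays within the scatter (a 1.1-fold lower number from compound 1 to compound 3 (0.04 log units; within the scatter)), so this change at this aromatic carbon, meta to a large group and para to a large group, produces no real shift that the test can detect. The earlier step concerned a chlorine elsewhere on the molecule, whereas this one is a direct reading of the position itself: here the core of compound 1 takes on a chlorine with no loss or gain in antiproliferative activity that stands out from repeat-to-repeat variation. No measured information is available to explain this result.

A single chloro cannot show whether the same holds for other groups on this carbon, and a methoxy group, an amine or a carboxylic acid might give quite a different result. The compounds shown also leave open whether chloro would be as readily accepted on the other carbons of this ring.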